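Phenyl for Methoxy on Two Related Chromone Amide Cores

The source may hold more compounds than are shown below. What is called first, only, known or untested is meant among the compounds shown, and "the series" means these compounds.

Compound 1 `COc1ccc(NC(=O)COc2ccc3oc(-c4ccccc4)cc(=O)c3c2)cc1` is an amide built on one core; compound 2 `O=C(COc1ccc2oc(-c3ccccc3)cc(=O)c2c1)Nc1ccc(-c2ccccc2)cc1` keeps that core but carries phenyl in place of methoxy on an aromatic carbon. In a functional assay on NPC-TW01 cells (Homo sapiens) for antiproliferative activity, read by MTT assay, with a stated time of 72 h (on this read-out higher numbers stand for weaker inhibition of growth and lower numbers for stronger inhibition of growth), compound 1 gives 710 nM, and compound 2 gives 640 nM; the change produced a 1.1-fold lower number from compound 1 to compound 2 (0.05 log units; within the scatter).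

Compound 3 `COc1ccc(NC(=O)COc2ccc3c(=O)c(-c4ccccc4)coc3c2)cc1` is made of the same atoms as compound 1, joined differently; the difference between the two cores is not broken down here. In this assay compound 3 gives 6700 nM, the highest of the three numbers, beyond the scatter from both compound 1 and compound 2.

Compound 4 `O=C(COc1ccc2c(=O)c(-c3ccccc3)coc2c1)Nc1ccc(-c2ccccc2)cc1` stands to compound 3 as compound 2 stands to compound 1: it carries phenyl in place of methoxy on an aromatic carbon, the same change, at the same place. Because that change gave a 1.1-fold lower number from compound 1 to compound 2 (0.05 log units; within the scatter), compound 4 is expected to sit close to compound 3, with the step from compound 3 to compound 4 estimated at a 1.1-fold lower number from compound 3 to compound 4 (0.05 log units; within the scatter). The estimated value for compound 4 in this assay is 6000 nM, expected to fall between 2500 nM and 15000 nM.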

Compound 4, concentration for 50% growth inhibition: 1750 nM
The estimate for compound 4 lay 3.4-fold (0.54 log units) above the measured number; measured number below the stated range.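

The same swap of methoxy for phenyl did not have the same effect on both cores: in this assay it gave a 3.8-fold lower number from compound 3 to compound 4 (0.58 log units; beyond the scatter), whereas on the other core it gave a 1.1-fold lower number from compound 1 to compound 2 (0.05 log units; within the scatter). The size of this step therefore depends on the core it is made on, and a step read on one core is a poor guide to the other: the same change on two cores in this assay, a 1.1-fold lower number (0.05 log units; within the scatter) from compound 1 to compound 2 and a 3.8-fold lower number (0.58 log units; beyond the scatter) from compound 3 to compound 4, 3.5-fold (0.54 log units) apart, beyond the scatter of two such steps This does not show why the two cores respond differently, and two pairs in a single assay say nothing about other changes or other cores.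

The compounds shown carry only methoxy or phenyl at this place, so it stays open how an amine or a carboxylic acid there would behave on each core. From the compounds shown here alone, it also stays open whether the two cores would still differ in this way with a longer chain in the linker that holds the amide.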